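A few compounds are considered here, and "the series" means these few. Any claim that something is new, unique, unknown or untested is made for them only; others in the source may bear on it.

Compound 1, whose structure is `N=C(N)c1ccc2oc(-c3ccc(OCCCCOc4ccccc4)cc3)cc2c1`, was tested in an ADME assay on L6 cells (Rattus norvegicus) for cytotoxicity, read by resazurin assay, with a stated time of 70 h (a higher number here means a weaker inhibitor, a lower number a stronger inhibitor), where compound 1 gives 1300 nM. Compound 2, drawn as `CC(C)NC(=N)c1ccc2oc(-c3ccc(OCCCCOc4ccccc4)cc3)cc2c1`, is the same molecule with isopropyl in place of hydrogen on an amine nitrogen, and in this assay compound 2 gives 6900 nM. That single change produced a 5.3-fold higher number from compound 1 to compound 2 (0.72 log units; beyond the scatter), so the isopropyl group made the compound noticeably less harmful to the cells.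

Compound 3, with structure `N=C(N)c1ccc2cc(-c3ccc(OCCCOc4ccccc4)cc3)oc2c1`, carries a different core; the difference between the two cores is not broken down here. In this assay compound 3 gives 8600 nM, a number close to that of compound 2 and well apart from that of compound 1.

Compound 4, whose structure is `CC(C)NC(=N)c1ccc2cc(-c3ccc(OCCCOc4ccccc4)cc3)oc2c1`, stands to compound 3 exactly as compound 2 stands to compound 1: it carries isopropyl in place of hydrogen on an amine nitrogen, at a place described in the same words as before, so it is the same change. For the measured compounds named here, only one earlier example of this change is available, which is thin ground, but it points in one direction. If the change behaves as it did from compound 1 to compound 2, compound 4 is expected to show a 3.5-fold higher number from compound 3 to compound 4 (0.54 log units; beyond the scatter), a step estimated to resemble a 5.3-fold higher number from compound 1 to compound 2 (0.72 log units; beyond the scatter). On that basis compound 4 is expected to give about 30000 nM in this assay, with a likely range from 10000 nM to 90000 nM.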

Compound 4, half-maximal inhibitory concentration: 49900 nM
The estimate for compound 4 lay 1.7-fold (0.22 log units) below the measured number; measured number inside the range.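

Isopropyl in place of hydrogen on an amine nitrogen again raised the number in this assay, with a 5.8-fold higher number from compound 3 to compound 4 (0.76 log units; beyond the scatter), so the substituted compound was again the less harmful to the cells. Set beside the earlier case, the change behaved alike on both cores: the same change on two cores in this assay, a 5.3-fold higher number (0.72 log units; beyond the scatter) from compound 1 to compound 2 and a 5.8-fold higher number (0.76 log units; beyond the scatter) from compound 3 to compound 4, 1.1-fold (0.04 log units) apart, within the scatter of two such steps. In these two pairs, then, both the direction and the size of the step carried over from one core to the other, but two pairs are a small sample, and they show neither why the step arises nor whether it would hold on any further core.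

The compounds shown leave open whether a different group on the same amine nitrogen, such as methyl, ethyl or cyclopentyl, would give a step of similar size, which would show how much depends on isopropyl itself. They also leave open whether the step would persist in a compound with a longer chain joining the two outer rings, or with an amine or a carboxylic acid added elsewhere in the molecule.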